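Pyrazinoyl to triazolylmethyl-carbamoyl on the shared core

The source may hold more compounds than are shown below. What is called first, only, known or untested is meant among the compounds shown, and "the series" means these compounds.

Measured so far:
compound 1 `Cc1cnc(C(=O)N2C[C@@H](O[C@H](C)c3cc(C(F)(F)F)cc(C(F)(F)F)c3)[C@H](c3ccc(F)cc3)C2)cn1`: 0.12 nM
compound 2 `C[C@@H](O[C@@H]1CN(C(=O)N2CCOCC2)C[C@H]1c1ccccc1)c1cc(C(F)(F)F)cc(C(F)(F)F)c1`: 0.16 nM

In an assay on CHO cells for displacement of a labelled ligand from Substance-P receptor (Homo sapiens) (a lower number here means a stronger inhibitor, a higher number a weaker inhibitor), compound 1 gives 0.12 nM, the lowest of the two numbers, while compound 2 gives 0.16 nM; the two lie within the usual scatter of each other. Compound 3 `C[C@@H](O[C@@H]1CN(C(=O)NCc2cn[nH]n2)C[C@H]1c1ccc(F)cc1)c1cc(C(F)(F)F)cc(C(F)(F)F)c1` carries the change (((2H-1,2,3-triazol-4-yl)methyl)amino in place of 5-methylpyrazin-2-yl on a carbonyl carbon), giving the (5-methylpyrazin-2-yl)carbonyl to ((2H-1,2,3-triazol-4-yl)methyl)carbamoyl exchange. Going by the values given here, no measured pair shows this step, so its size is unknown; given that compound 2 holds 0.16 nM, a modest weakening, near the edge of scatter, is expected as a 2.5-fold higher number from compound 1 to compound 3 (0.40 log units; beyond the scatter). For compound 3 the estimate in this assay is 0.3 nM, range 0.08 nM to 1.5 nM.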

Compound 3, half-maximal inhibitory concentration: 0.58 nM
Estimate against measurement, compound 3: 1.9-fold (0.29 log units) below; the range from low to high includes it.
By their numbers in this assay, from the lowest: compounds 1 and 2 (each within the scatter of the next); then compound 3.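

The exchange of 5-methylpyrazin-2-yl for ((2H-1,2,3-triazol-4-yl)methyl)amino on this carbonyl carbon gives a 4.8-fold higher number from compound 1 to compound 3 (0.68 log units; beyond the scatter) in this assay and is a modest step. The position accepts a carbamoyl link with a five-membered aromatic ring at some cost, and compound 3 still reads 0.58 nM in this assay on the shared core. Nothing available bears on the reason for the step.

As far as these compounds go, the ring and the amino link change together, so their separate shares remain open. A simple dimethylamino group on the same carbonyl carbon would help to separate them.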